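Replacing the chlorofuran arm of compound 1

The source may report more compounds than this note shows. Statements on the series, on what has been measured and on what is new or still open speak of the compounds shown alone.

Within the data shown here, compound 1 `COc1ccc(CNC(=O)/C(C#N)=C/c2ccc(Cl)o2)cc1` is the only compound with a numerical value: in a functional assay on SMA cells (Homo sapiens) for inhibition, read by MTT assay, with a stated time of 72 h (on this read-out lower numbers stand for stronger inhibition of growth and higher numbers for weaker inhibition of growth), compound 1 gives 14000 nM. Compound 2 `COc1ccc(CNC(=O)/C(C#N)=C/c2ccc(-c3ccccc3)o2)cc1` reaches only a limit of this assay, with compound 2 at > 100000 nM. Among the measured compounds shown here, the one measured step, an at least 7.1-fold higher number from compound 1 to compound 2 (0.85 log units; beyond the scatter), shows that a phenyl in place of chloro on an aromatic carbon weakens growth inhibition clearly, the size of that step being set by the limit of > 100000 nM in this assay, at which 1 of the 2 values shown sits.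

Compound 3 `COc1ccc(CNC(=O)/C(C#N)=C/c2ccc(C)cc2)cc1` differs from compound 1 by 4-methylphenyl in place of 5-chlorofuran-2-yl on a double-bonded chain carbon bound to a double-bonded chain carbon. This is a different change from the measured one, since the whole five-membered ring leaves rather than a substituent on it, so the step from compound 1 to compound 2 bears on it only loosely: it shows that a change at this end of the molecule can weaken growth inhibition strongly. A step in the same direction, weaker than compound 1 but probably smaller than the measured step, is expected. Compound 3 is therefore estimated at 30000 nM, with a range from 10000 nM to 100000 nM, which means an expected step of a 2.1-fold higher number from compound 1 to compound 3 (0.33 log units; beyond the scatter).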

Compound 3, concentration for 50% growth inhibition: 42000 nM
Beside the measured number, compound 3's estimate is 1.4-fold (0.15 log units) below it; the measured number falls inside the stated range.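

In this assay, exchanging the whole 5-chlorofuran-2-yl arm for 4-methylphenyl on the double-bonded chain carbon gives a 3.0-fold higher number from compound 1 to compound 3 (0.48 log units; beyond the scatter). Among these compounds, this is the first step with a number at both ends, so it shows that growth inhibition at this position does not depend on keeping the five-membered ring: a six-membered aromatic ring of carbon only still gives a readable value, though a weaker one than compound 1. The earlier step to compound 2 gives only a lower bound on its size, and compound 3 and compound 2 can be set side by side only as far as their printed values allow: the limit of > 100000 nM in this assay, at which 1 of the 3 values shown sits.

Compound 3 changes the ring and its substituent together, so the step does not say how much of the weakening belongs to the loss of the furan ring and how much to the loss of the chlorine; a 4-chlorophenyl arm or a 5-methylfuran-2-yl arm would separate the two. On these data alone, how this position responds to an amine or a carboxylic acid on the aromatic ring also remains open.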